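This account rests on a few compounds, and the source may have more. Where it says the series, first, only, none or still open, it means among the compounds named here.

Compound 1 `Cc1c(CCCC(=O)O)c2cccc(/C=C/c3ccc(OCCCCc4ccccc4)cc3)c2n1CC(=O)O` was examined in a functional assay on HEK293 cells for antagonist activity at cysteinyl leukotriene receptor 2 (Homo sapiens), read by fluorescence and calcium flux, with stated times of 30 min and 1 h (on this read-out higher numbers stand for weaker inhibition and lower numbers for stronger inhibition), where compound 1 gives 4.7 nM. The only other measured compound, compound 2 `Cc1c(Cl)cccc1CCCCOc1ccc(C#Cc2cccc3c(CCCC(=O)O)c(C)n(CCCCC(=O)O)c23)cc1`, gives 30 nM in this assay, a higher number whose gap to compound 1 lies beyond the usual scatter, so compound 1 stands as the lower of the two numbers shown. Compound 3 `Cc1c(CCCC(=O)O)c2cccc(/C=C/c3ccc(OCCCCc4c(F)ccc(F)c4F)cc3)c2n1CC(=O)O` has not yet been measured. It differs from compound 1 in one place: 2,3,6-trifluorophenyl in place of phenyl on a saturated chain carbon, four bonds along the chain from an oxygen on an aromatic ring. Among the compounds with values here, no measured pair shows this same change, so the step from compound 1 to compound 3 cannot be read off from existing data and must be judged from the change alone. The expectation is a step that stays within the scatter, a 1.2-fold higher number from compound 1 to compound 3 (0.07 log units; within the scatter), with no clear direction. Compound 3 is therefore expected to give about 5.5 nM in this assay, within a range from 1.8 nM to 17 nM.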

Compound 3, half-maximal inhibitory concentration: 1 nM
Compound 3: the middle estimate sits 5.5-fold (0.74 log units) above what was measured, and the stated range ends above it.
By their numbers in this assay, from the lowest: compound 3; then compound 1; then compound 2.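

In this assay, swapping phenyl for 2,3,6-trifluorophenyl on a saturated chain carbon, four bonds along the chain from an oxygen on an aromatic ring, gives a 4.7-fold lower number from compound 1 to compound 3 (0.67 log units; beyond the scatter), a modest step that means stronger inhibition. Within the data shown here, this is the first view of a single change at this place, since compound 1 and compound 2 differ in more than one place, and it shows that the ring at the end of this chain can carry three fluorine atoms without any loss of inhibition. No measurement here says why the number falls.

Among these compounds, with only this one pair, it remains open whether all three fluorine atoms are needed, or whether 2-fluorophenyl or 2,6-difluorophenyl would give a similar step. Also open, going by these compounds, is how a pyridine ring or a longer chain would fare at this place.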